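From compound 2 to a bare phenyl

A few compounds are considered here, and "the series" means these few. Any claim that something is new, unique, unknown or untested is made for them only; others in the source may bear on it.

In a functional assay on KM12 cells (Homo sapiens) for inhibition, read by sulforhodamine B assay, with a stated time of 48 h (on this read-out higher numbers stand for lower toxicity in this test and lower numbers for higher toxicity in this test), compound 1 `COc1cc(-c2nn(-c3cccc(NC(=O)Nc4ccc(Cl)c(Cl)c4)c3)cc2-c2ccncc2)ccc1Cl` gives 49500 nM. Compound 2 `COc1cc(-c2nn(-c3cccc(NC(=O)c4ccc(Cl)c(C(F)(F)F)c4)c3)cc2-c2ccncc2)ccc1Cl` gives > 32500 nM, which is a limit of the assay and not a number. Compound 3 `COc1cc(-c2nn(-c3cccc(NC(=O)c4ccccc4)c3)cc2-c2ccncc2)ccc1Cl` differs from compound 2 in one place: phenyl in place of 4-chloro-3-(trifluoromethyl)phenyl on a carbonyl carbon. For the measured compounds named here, the only measured step nearby is a step that the limit leaves unreadable from compound 1 to compound 2, so its size offers no guide, and the evidence on it is the limit of > 32500 nM in this assay, at which 1 of the 2 values shown sits. With no readable step to go on, the value of compound 1 is the best anchor, and little change is expected in this assay, an estimated step that the limit leaves unreadable from compound 2 to compound 3. Compound 3 is expected at 45000 nM, within an estimated range of 20000 nM to 100000 nM.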

Compound 3, concentration lethal to 50% of the cells: > 100000 nM
Compound 3: only a limit was reported; the forecaster's own chance of this, stated with the estimate: 60%; at least 2.2-fold (0.34 log units) between middle value and limit.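

For the compounds shown here, the first step at this position that can be read is from the urea side: on the carbonyl carbon, phenyl in place of (3,4-dichlorophenyl)amino gives an at least 2.0-fold higher number from compound 1 to compound 3 (0.30 log units; that floor lies within the scatter) in this assay. That step is only a floor, and the step between the two amides cannot be read. Compound 3 stands at a limit of the assay and not at a number: the limit of > 100000 nM in this assay, at which 1 of the 3 values shown sits.

Going by these compounds, neither amide has a number here, so the effect of the chlorine and trifluoromethyl on the ring stays open. So does the effect of a phenyl carrying an amine or a carboxylic acid on the same carbonyl carbon.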